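Notes on the anilino change from compound 2 to compound 3

The source may hold more compounds than are shown below. What is called first, only, known or untested is meant among the compounds shown, and "the series" means these compounds.

Measured so far:
compound 1 `C#CCSc1nc(Nc2ccccc2Cl)c(C#N)c(-c2ccccc2)n1` — in a functional assay on B16-F10 cells (Mus musculus) for inhibition, read by MTT assay, with a stated time of 72 h (on this read-out higher numbers stand for weaker inhibition and lower numbers for stronger inhibition), compound 1 gives 12400 nM
compound 2 `COc1ccc(Nc2nc(SCc3cn(Cc4ccccc4Cl)nn3)nc(-c3ccccc3)c2C#N)cc1` — in this assay compound 2 gives 3990 nM

Compound 2 stands at the lowest of the two numbers; compound 1 reads higher by a gap beyond the usual scatter. Among the measured compounds shown here, the two measured compounds differ in two places at once, so no single-change step is available, and what the anilino part alone contributes cannot be read off. Compound 3 `N#Cc1c(Nc2ccccc2Cl)nc(SCc2cn(Cc3ccccc3Cl)nn2)nc1-c1ccccc1` keeps the thioether side of compound 2 and takes the change (2-chlorophenyl in place of 4-methoxyphenyl on a nitrogen on an aromatic ring). For the measured compounds named here, the only guide is that compound 1, which carries the same 2-chlorophenyl group on that nitrogen, gives 12400 nM in this assay. A step toward a higher number is therefore expected, of moderate size and possibly beyond the scatter, as a 1.9-fold higher number from compound 2 to compound 3 (0.27 log units; within the scatter). For compound 3 the estimate is 7500 nM, with a range from 2500 nM to 22000 nM.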

Compound 3, half-maximal inhibitory concentration: 8350 nM
Compound 3: the middle estimate sits 1.1-fold (0.05 log units) below what was measured; measured number inside the range.
By their numbers in this assay, from the lowest: compound 2; then compounds 3 and 1 (each within the scatter of the next).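

In this assay, placing 2-chlorophenyl in place of 4-methoxyphenyl on a nitrogen on an aromatic ring gives a 2.1-fold higher number from compound 2 to compound 3 (0.32 log units; beyond the scatter). Among the compounds shown here, this is the first reading of this position with the rest of the molecule held fixed, and it shows that the number responds to the group on that nitrogen, though the step is modest and only just clears the usual scatter. No measured information on the compounds bears on the reason for this step.

With only these two groups compared at this position, the contributions of the chlorine, the methoxy group and their placement on the ring remain inseparable. As far as these compounds go, how an unsubstituted phenyl group, or a saturated amine such as morpholine in place of the anilino group, would read at this position remains open.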